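The compounds below may be only part of what the source reports. "The series", "measured", "known", "first", "only" and "open" are said of these compounds alone.

Compound 1 `COc1ccc(NC(=O)Oc2cc(=O)n(CCCO)c3c2CC(C/C=C(\C)CCC=C(C)C)C(C)(C)C3)cc1`: 64.1%
Compound 2 `CC(C)=CCC/C(C)=C/CC1Cc2c(OC(=O)Nc3cccc(F)c3)cc(=O)n(CCCO)c2CC1(C)C`: 52.3%
Compound 3 `CC(C)=CCC/C(C)=C/CC1Cc2c(OC(=O)Nc3ccc(F)c(F)c3)cc(=O)n(CCCO)c2CC1(C)C`: 43.7%

In a functional assay on PANC-1 cells (Homo sapiens) for inhibition, read by MTT assay, with a stated time of 24 h, tested at 10 uM (a higher number here means more inhibition at the concentration tested (going by the name of the read-out), a lower number less inhibition), compound 3 gives the lowest of the three numbers. Its distance from compound 1 is a number 20.4 percentage points lower from compound 1 to compound 3 (beyond the scatter), beyond the scatter, whereas the step of a number 8.6 percentage points lower from compound 2 to compound 3 (within the scatter) stays within it. Compound 4 `CC(C)=CCC/C(C)=C/CC1Cc2c(OC(=O)Nc3ccc(F)c(Cl)c3)cc(=O)n(CCCO)c2CC1(C)C` differs from compound 3 by a single exchange: chloro in place of fluoro on an aromatic carbon. Within the data shown here, no measured step swaps chloro for fluoro; the nearest comparison is a number 8.6 percentage points lower from compound 2 to compound 3 (within the scatter), a change on the same ring that did not exceed the scatter. Compound 4 is therefore expected to land near compound 3, with a number 2.3 percentage points higher from compound 3 to compound 4 (within the scatter) as the expected step, not clearly beyond the scatter. The estimate for compound 4 in this assay is 46%, ranging from 33% to 59%.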

Compound 4, a percentage reported as inhibition, at one concentration (the size of the read-out at that concentration, not a potency): 25%
Compound 4: middle estimate off by 21 percentage points, on the high side, and the stated range ends above it.
By their numbers in this assay, from the lowest: compound 4; then compounds 3 and 2 (each within the scatter of the next); then compound 1.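

In this assay, the halogen ortho to a fluoro group matters: chloro in place of fluoro gives a number 18.7 percentage points lower from compound 3 to compound 4 (beyond the scatter) and is a clear change, unlike the addition of fluoro on the same ring, a number 8.6 percentage points lower from compound 2 to compound 3 (within the scatter) on the same scale. The 3-chloro-4-fluorophenyl group also stands apart from the other two groups on the amide-type nitrogen, with a number 27.3 percentage points lower from compound 2 to compound 4 (beyond the scatter) and a number 39.1 percentage points lower from compound 1 to compound 4 (beyond the scatter) as the steps. Nothing available explains why chloro differs from fluoro here. From the compounds shown here alone, how a bromo, methyl or methoxy group would read at this position remains open.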